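The compounds below may be only part of what the source reports. "The series", "measured", "known", "first", "only" and "open" are said of these compounds alone.

Measured so far:
- compound 1 `COc1ccc(F)cc1-c1c(F)cnc2[nH]c(C3=CCN([C@H]4CC[C@@H](C(=O)O)CC4)CC3)cc12`: 13%
- compound 2 `COc1ccc(F)cc1-c1ccnc2[nH]c(C3=CCN([C@H]4CC[C@@H](C(=O)O)CC4)CC3)cc12`: 20%
- compound 3 `COc1ccc(F)cc1-c1ccnc2[nH]c(C3=CCC(N[C@@H](C(=O)O)C(C)C)CC3)cc12`: 0.2%

In an ADME assay on the whole organism (Rattus norvegicus) for pharmacokinetics, at a dose of 1 mg/kg by the oral route (a higher number here means that a larger share of the oral dose reaches the circulation, a lower number that a smaller share of the oral dose reaches the circulation), compound 1 gives 13%, the second highest of the three numbers; compound 2 lies a number 7 percentage points higher from compound 1 to compound 2 (within the scatter), and compound 3 sits far lower at 0.2%. Compound 4 `COc1ccc(F)cc1-c1c(F)cnc2[nH]c(C3=CCN([C@H]4CC[C@H](CC(=O)O)CC4)CC3)cc12` differs from compound 1 in one place: 4-(carboxymethyl)cyclohexyl in place of 4-carboxycyclohexyl on an amine nitrogen in a ring. For the measured compounds named here, no measured step touches this part of the molecule, since the only single-point step, a number 7 percentage points higher from compound 1 to compound 2 (within the scatter), concerns a fluoro on the shared core, and compound 3 differs from compound 1 in more than one place. Without a comparable step, the expectation is for a change no larger than the scatter, so compound 4 is estimated at 13% (range 4% to 28%), which means an expected step of no change at the digits printed from compound 1 to compound 4 (within the scatter).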

Compound 4, oral bioavailability: 11%
The estimate for compound 4 lay 2 percentage points above the measured number; low and high end bracket the measured number.
By their numbers in this assay, from the lowest: compound 3; then compounds 4, 1 and 2 (each within the scatter of the next).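

In this assay, 4-(carboxymethyl)cyclohexyl in place of 4-carboxycyclohexyl on the amine nitrogen in a ring gives a number 2 percentage points lower from compound 1 to compound 4 (within the scatter). For the compounds shown here, this is the first single-place step read at this part of the molecule, and it shows that the longer acid-bearing group leaves oral bioavailability within the scatter. The data shown give no reason for this result. From the compounds shown here alone, whether an amine or an amide in place of the carboxylic acid would keep oral bioavailability in this range stays open. So does whether a still longer chain would do so.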